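This account rests on a few compounds, and the source may have more. Where it says the series, first, only, none or still open, it means among the compounds named here.

Compound 1 `Cc1ccc2c(C3CCN(CCN4CCN(C(C)C)C4=O)CC3)cn(-c3ccccc3)c2c1` carries a phenyl group on the shared core, and in an assay on cell membranes for displacement of a labelled ligand from Adrenergic receptor alpha-1 (Rattus norvegicus) (on this read-out lower numbers stand for stronger inhibition and higher numbers for weaker inhibition), compound 1 gives 120 nM. Compound 2 `Cc1ccc2c(C3CCN(CCN4CCN(C(C)C)C4=O)CC3)cn(-c3ccccc3F)c2c1` differs from it only by fluoro in place of hydrogen on an aromatic carbon; in this assay compound 2 gives 370 nM, which is a 3.1-fold higher number from compound 1 to compound 2 (0.49 log units; beyond the scatter). Compound 3 `CC(C)N1CCN(CCN2CCC(c3cn(-c4ccccc4)c4cc(Cl)ccc34)CC2)C1=O` keeps the phenyl group but differs from compound 1 in the core by chloro in place of methyl on an aromatic carbon; compound 3 gives 39 nM, the lowest of the three numbers, and the step is a 3.1-fold lower number from compound 1 to compound 3 (0.49 log units; beyond the scatter). Compound 4 `CC(C)N1CCN(CCN2CCC(c3cn(-c4ccccc4F)c4cc(Cl)ccc34)CC2)C1=O` has not yet been measured. It arises from compound 3 by fluoro in place of hydrogen on an aromatic carbon, the same change that turned compound 1 into compound 2, occurring twice among these compounds, and the place of the change reads the same in both cases. Among the measured compounds shown here, the only precedent is the step on the core of compound 1, which was a 3.1-fold higher number from compound 1 to compound 2 (0.49 log units; beyond the scatter), so the step from compound 3 to compound 4 is expected to be of similar size, a 3.1-fold higher number from compound 3 to compound 4 (0.49 log units; beyond the scatter), though a single precedent leaves room for error. Compound 4 is therefore estimated at 120 nM, with a likely range from 50 nM to 300 nM.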

Compound 4, half-maximal inhibitory concentration: 120 nM
For compound 4 middle estimate and measured number coincide at the digits printed; measured number inside the range.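

In this assay the change from phenyl to 2-fluorophenyl gives a 3.1-fold higher number from compound 3 to compound 4 (0.49 log units; beyond the scatter), which repeats the earlier step on the other core: the same change on two cores in this assay, a 3.1-fold higher number (0.49 log units; beyond the scatter) from compound 1 to compound 2 and a 3.1-fold higher number (0.49 log units; beyond the scatter) from compound 3 to compound 4, 1.0-fold (0.00 log units) apart, within the scatter of two such steps Read the other way, chloro in place of methyl on an aromatic carbon gives a 3.1-fold lower number from compound 2 to compound 4 (0.49 log units; beyond the scatter), and this step repeats as well: the same change on two cores in this assay, a 3.1-fold lower number (0.49 log units; beyond the scatter) from compound 1 to compound 3 and a 3.1-fold lower number (0.49 log units; beyond the scatter) from compound 2 to compound 4, 1.0-fold (0.00 log units) apart, within the scatter of two such steps Both comparisons rest on the same small set of compounds, so they show that each change kept its size when carried between these two cores, but they do not show that it would do so on any other core or with any other group.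

The compounds shown leave open how the step from phenyl to 2-fluorophenyl would read with a methoxy group or a nitrile in place of the chloro on the core. They also leave open whether a methoxy group or a nitrile in place of the fluoro would carry over between cores in the same way.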